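Fluorinated nucleosides: amino against hydroxy on the base

The source may report more compounds than this note shows. Statements on the series, on what has been measured and on what is new or still open speak of the compounds shown alone.

Compound 1 `Nc1ccn([C@@H]2CC(F)(F)[C@H](CO)O2)c(=O)n1` gives in a functional assay on CCRF-CEM cells (Homo sapiens) for cytotoxicity (a lower number here means a stronger inhibitor, a higher number a weaker inhibitor), a reading of > 100000 nM, which is a limit of the assay and not a number.
Compound 2 `O=c1nc(O)ccn1[C@@H]1CC(F)(F)[C@H](CO)O1` gives in this assay a reading of > 100000 nM, again a limit.
Compound 3 `Nc1ncnc2c1ncn2[C@@H]1CC(F)(F)[C@H](CO)O1` gives in this assay a reading of > 100000 nM, also a limit.

The change from compound 1 to compound 2 is hydroxy in place of amino on an aromatic carbon. The step that the two limits leave unreadable from compound 1 to compound 2 cannot be read because the limit of > 100000 nM in this assay, at which 3 of the 3 values shown sit, holds both values. How the core of compound 1 and the core of compound 3 differ is not broken down here.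

Compound 4 `OC[C@@H]1O[C@H](n2cnc3c(O)ncnc32)CC1(F)F` has not been measured. It differs from compound 3 by hydroxy in place of amino on an aromatic carbon. This is the same kind of change as from compound 1 to compound 2, but the surroundings differ: in compound 3 the ring is part of a fused or bridged system of two rings, with the carbon ortho to a fused ring and meta to a fused ring, whereas in compound 1 the carbon is meta to a group of 1 heavy atom and para to a group of 9 heavy atoms.

The step expected from compound 3 to compound 4 is a step that the limit leaves unreadable from compound 3 to compound 4, set beside a step that the two limits leave unreadable from compound 1 to compound 2, and it rests on (the limit of > 100000 nM in this assay, at which 3 of the 3 values shown sit), where compound 1, compound 2 and compound 3 all sit. For compound 4 the expected reading in this assay is 200000 nM, most likely again only a limit, with a range from 50000 nM to 1000000 nM.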

Compound 4, half-maximal inhibitory concentration: > 100000 nM
Compound 4: only a limit was reported; the forecaster's own chance of this, stated with the estimate: 90%; the middle value does not contradict the limit.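

No step can be read from compound 3 to compound 4, and the change from amino to hydroxy remains as unreadable there as between compound 1 and compound 2, because all four readings sit at one limit: the limit of > 100000 nM in this assay, at which 4 of the 4 values shown sit.

Whether amino or hydroxy on the base makes any difference in this assay stays open, with no actual number among the compounds shown.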